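The source may report more compounds than this note shows. Statements on the series, on what has been measured and on what is new or still open speak of the compounds shown alone.

Measured so far:
- compound 1, `N#Cc1cccc(CN2C(=O)N(Cc3ccccc3)S(=O)(=O)n3cccc32)c1` — > 318000 nM in an ADME assay on MT4 cells (Homo sapiens) for cytotoxicity, read by MTT assay, with a stated time of 5 days; on this read-out lower numbers stand for higher toxicity in this test and higher numbers for lower toxicity in this test
- compound 2, `O=C1N(Cc2ccc(Cl)cc2Cl)c2cccn2S(=O)(=O)N1Cc1cccc(F)c1` — > 249000 nM
- compound 3, `CC(C)=CCN1C(=O)N(Cc2ccccc2)S(=O)(=O)n2cccc21` — 226000 nM

The value of compound 1 in this assay is a limit of the assay, not a number. The value of compound 2 is likewise a limit. Among the measured compounds shown here, compound 3 therefore stands as the only plain number among the three; the two others sit at their limits, the limit of > 249000 nM in this assay, at which 1 of the 3 values shown sits, and (the limit of > 318000 nM in this assay, at which 1 of the 3 values shown sits).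

Compound 4, `O=C1N(Cc2ccc(Cl)cc2Cl)c2cccn2S(=O)(=O)N1Cc1ccccc1`, is still to be measured. It differs from compound 3 in one place: 2,4-dichlorophenyl in place of 2-methylprop-1-en-1-yl on a saturated chain carbon bound to an amide-type nitrogen in a ring.

For the measured compounds named here, only one measured step touches the same place. It is an at least 1.4-fold lower number from compound 1 to compound 3 (0.14 log units; that floor lies within the scatter); that step stays within the scatter, and it runs in the other direction, from an aromatic ring towards the chain. Compound 2 carries the entering 2,4-dichlorobenzyl group and reaches only a limit in this assay, though it is not a one-place neighbour of compound 4.

Taken together, no step beyond the scatter is expected from compound 3 to compound 4 in this assay; the expected step is a 1.2-fold higher number from compound 3 to compound 4 (0.06 log units; within the scatter), and the result may again come out as a limit. The estimate for compound 4 is 260000 nM, between 120000 nM and 450000 nM.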

Compound 4, half-maximal cytotoxic concentration: 218000 nM
Beside the measured number, compound 4's estimate is 1.2-fold (0.08 log units) above it; the range from low to high includes it.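

In this assay, this place now has a comparison with plain numbers at both ends, and it gives a 1.0-fold lower number from compound 3 to compound 4 (0.02 log units; within the scatter): the open 3-methylbut-2-en-1-yl chain and the ring-bearing 2,4-dichlorobenzyl group cannot be told apart here. Compound 1 and compound 2 are given only as limits of the assay, so their steps give only floors: an at least 1.4-fold lower number from compound 1 to compound 4 (0.16 log units; that floor lies within the scatter) at this same place, and an at least 1.1-fold lower number from compound 2 to compound 4 (0.05 log units; that floor lies within the scatter) where hydrogen takes the place of fluoro on an aromatic carbon. Thus, with 3-cyanophenyl, 2-methylprop-1-en-1-yl and 2,4-dichlorophenyl at this place, one a chain and two aromatic rings, none of the steps shown goes beyond the usual scatter of the assay.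

From the compounds shown here alone, whether a group of another kind at this place, such as an amine, a carboxylic acid or a longer chain, would move the number in this assay stays open. With compound 1 and compound 2 known only as limits, the full size of their steps to compound 4 also stays unsettled.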